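Adding a Hydroxy Group to a Hydroxamic Acid Chain

The compounds below may be only part of what the source reports. "The series", "measured", "known", "first", "only" and "open" are said of these compounds alone.

Going by the values given here, compound 2 `O=C(CCCCCCCCc1ccc2ccccc2c1)NO` is one of two compounds measured in an assay on isolated protein for inhibition of histone deacetylase 8 (Homo sapiens); on this read-out higher numbers stand for weaker inhibition and lower numbers for stronger inhibition. In this assay compound 2 gives 25 nM, which is the higher of the two numbers and so the weaker inhibition. The other measured compound, compound 1 `O=C(CCCCCCCC(=O)c1ccc(-c2ccc(Br)cc2)cc1)NO`, gives 2 nM in this assay; the gap between these two values lies beyond the usual scatter, so compound 1 is the stronger inhibitor of the pair. The two structures differ in more than one place, so their values can only be compared side by side, not traced to a single change.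

Compound 3 `O=C(CCCCCCCC(O)c1ccc2ccccc2c1)NO` is the next compound to be measured. It differs from compound 2 in a single place: hydroxy in place of hydrogen on a saturated chain carbon bound to an aromatic carbon and a saturated chain carbon. Among the compounds with values here, no pair of measured compounds shows exactly this kind of change, so the size of the step is uncertain. Compound 3 is expected to come in at 15 nM, within a range from 5 nM to 60 nM. The expected step of a 1.7-fold lower number from compound 2 to compound 3 (0.22 log units; within the scatter) is a small one, likely within or just beyond the scatter, with the direction leaning toward somewhat stronger inhibition because compound 1, which carries an oxygen on its chain, shows 2 nM.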

Compound 3, half-maximal inhibitory concentration: 35 nM
For compound 3 the middle estimate is 2.3-fold (0.37 log units) below the measured one; the measured number falls inside the stated range.
By their numbers in this assay, from the lowest: compound 1; then compounds 2 and 3 (each within the scatter of the next).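

Placing hydroxy in place of hydrogen on a saturated chain carbon bound to an aromatic carbon and a saturated chain carbon gives, in this assay, a 1.4-fold higher number from compound 2 to compound 3 (0.15 log units; within the scatter). Going by these compounds alone, this is the first single-place step, and it shows that this chain position can take a hydroxy group, which brings in one oxygen, one hydrogen-bond donor and one hydrogen-bond acceptor, with no change in the read-out beyond the scatter. No measurement is at hand that explains this result.

On these data alone, a single step at one position shows no trend, so it remains open whether an amine or a methoxy group on this same saturated chain carbon would also stay within the scatter or would give a clear step in either direction. As far as these compounds go, it also remains open whether the hydroxy step would keep its size on a longer chain or on the core of compound 1, which differs from compound 3 in more than one place and so cannot be compared with it directly.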